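Swapping Phenyl for Thiophene on an Ester Carbonyl

The source may hold more compounds than are shown below. What is called first, only, known or untested is meant among the compounds shown, and "the series" means these compounds.

Of the compounds shown here, two have so far been measured in an assay on cells for displacement of a labelled ligand from Orexin/Hypocretin receptor type 1 (Homo sapiens), read by scintillation counting, with stated times of 10 min and 90 min, tested at 10 uM; a higher number here means more inhibition at the concentration tested (going by the name of the read-out), a lower number less inhibition. Compound 1 `O=C(O)c1ccc2ccc(C(=O)c3ccccc3)c-2cc1` gives 11%. Compound 2 `O=C(Oc1ccc2ccc(Cl)ccc1-2)c1ccccc1` gives 0.1%, the lowest of the two numbers, with compound 1 standing above it by a gap beyond the usual scatter. Compound 3 `O=C(Oc1ccc2ccc(Cl)ccc1-2)c1cccs1` has not yet been measured. It differs from compound 2 in a single place: thiophen-2-yl in place of phenyl on a carbonyl carbon. Within the data shown here, no step between two measured compounds shows what this exchange does on the shared core in this assay, so the expectation rests on compound 2 alone. Because compound 2 gives 0.1% in this assay, the step of a number 2.9 percentage points higher from compound 2 to compound 3 (within the scatter) is expected to stay within the usual scatter, with no clear direction. Compound 3 is therefore estimated at 3% in this assay, with a range from 0% to 14%.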

Compound 3, a percentage reported as inhibition, at one concentration (the size of the read-out at that concentration, not a potency): 9.8%
The estimate for compound 3 lay 6.8 percentage points below the measured number; the measured number falls inside the stated range.
By their numbers in this assay, from the lowest: compounds 2, 3 and 1 (each within the scatter of the next, the first and the last beyond it).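

Among these compounds, with thiophen-2-yl in place of phenyl on a carbonyl carbon, a number 9.7 percentage points higher from compound 2 to compound 3 (within the scatter) appears in this assay, giving the first direct reading of a change at this position. The five-membered sulfur-containing ring and the six-membered carbon ring therefore cannot be told apart here, and this single exchange gives no sign that the read-out depends on which of these two aromatic rings is present. Among the compounds shown here, nothing measured so far offers an explanation for this result. The compounds shown leave open whether a group of a different kind at this position, such as an amine, a carboxylic acid or a longer alkyl chain, would move the number beyond the scatter. They also leave open whether a substituted phenyl ring, for example one carrying methoxy, would do so.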